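The source may hold more compounds than are shown below. What is called first, only, known or untested is meant among the compounds shown, and "the series" means these compounds.

Measured so far:
compound 1, `CC[C@@H](Nc1c(C#N)c(-c2ccc(-c3ccccc3F)cc2)nc2cnccc12)C(N)=O`: 2.7
compound 2, `CC[C@@H](Nc1c(C#N)c(-c2ccc(Br)cc2)nc2cnccc12)C(=O)O`: 1.6

Both compounds were measured in a physicochemical assay for lipophilicity, read by HPLC, at pH 7.5; a higher number here means a more lipophilic compound, a lower number a more polar compound. Compound 1 gives 2.7, and compound 2 gives 1.6, so compound 1 has the higher of the two numbers, and the gap between them is wider than the usual scatter. Compound 3, `CC[C@@H](Nc1c(C#N)c(-c2ccc(-c3ccccc3C)cc2)nc2cnccc12)C(N)=O`, has not yet been measured in this assay. It differs from compound 1 in one place: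

methyl in place of fluoro on an aromatic carbon

Within the data shown here, since no pair of measured compounds shares exactly this change, no measured step can be quoted for it. Swapping fluoro for methyl on an aromatic carbon is a small change in atom count, and the expectation is a step of modest size in the upward direction, from compound 1 to compound 3 of a number 0.40 log units higher from compound 1 to compound 3 (beyond the scatter), possibly no larger than the scatter. Compound 3 is therefore expected to read about 3.1 in this assay, within a range from 2.7 to 3.5.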

Compound 3, distribution coefficient: 3
Estimate against measurement, compound 3: 0.10 log units above; low and high end bracket the measured number.
By their numbers in this assay, from the lowest: compound 2; then compounds 1 and 3 (each within the scatter of the next).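

In this assay, among these compounds, replacing the 2-fluorophenyl of compound 1 with the 2-methylphenyl of compound 3 gives a number 0.30 log units higher from compound 1 to compound 3 (within the scatter) and so provides the first measured step at this position, on an aromatic carbon ortho to a large group. Here, fluoro and methyl, each a single heavy atom, cannot be told apart by this read-out, which the earlier pair could not show since compound 1 and compound 2 differ in more than one place. Nothing at hand offers an explanation for this result.

Going by these compounds, it remains open whether an amine, a hydroxyl group or a longer chain such as propyl at this same place would stay within the scatter of compound 1. Also open, on these data alone, is whether fluoro and methyl would still read alike with a carboxylic acid in place of the amide.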